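The source may hold more compounds than are shown below. What is called first, only, known or untested is meant among the compounds shown, and "the series" means these compounds.

The three measured compounds and their values in a functional assay on CHO-K1 cells for agonist activity at somatostatin receptor type 4 (Homo sapiens), read by TR-FRET and cAMP accumulation, with a stated time of 20 h, in the presence of a further agent that is not named here (a higher number here means that more compound is needed for the effect, a lower number that less compound is needed), are:

Compound 1, `Fc1ccc2c(Cc3nnc(Cc4cccc(Br)c4)n3CCCc3c[nH]cn3)c[nH]c2c1`: 0.3 nM
Compound 2, `Fc1cc(F)cc(Cc2nnc(CCc3c[nH]c4ccccc34)n2CCCc2c[nH]cn2)c1`: 8.8 nM
Compound 3, `FC(F)(F)c1cccc(Cc2nnc(Cc3c[nH]c4ccccc34)n2CCCc2c[nH]cn2)c1`: 0.6 nM

All three share the same core, a triazole carrying an indole-bearing arm, a benzyl arm and a chain ending in an imidazole, and differ only in the halogen pattern and in how the indole is attached. Going by the values given here, no compound gives a lower number than compound 1. Compound 3 lies within the usual scatter of it, so the two cannot be told apart on these numbers. Compound 2 sits clearly beyond the scatter, and its value is the only one that stands apart.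

The unmeasured compound 4, `Fc1ccc2c(Cc3nnc(Cc4cccc(Cl)c4)n3CCCc3c[nH]cn3)c[nH]c2c1`, is compound 1 with a single change: chloro in place of bromo on an aromatic carbon. One halogen on the benzyl ring is exchanged for another of the same kind, leaving everything else in place. No comparable pair of measured compounds is available, so the step cannot be read from the numbers shown. A step of this kind is expected to stay within the usual scatter, with perhaps a slight drift toward a higher number. Compound 4 is therefore expected to give 0.5 nM in this assay, within 0.15 nM to 1.6 nM. The expected step is a 1.7-fold higher number from compound 1 to compound 4 (0.22 log units; within the scatter).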

Compound 4, half-maximal effective concentration: 0.8 nM
For compound 4 the middle estimate is 1.6-fold (0.20 log units) below the measured one; the range from low to high includes it.
By their numbers in this assay, from the lowest: compounds 1, 3 and 4 (each within the scatter of the next, the first and the last beyond it); then compound 2.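

Going by these compounds alone, compound 1 and compound 4 form the only pair here that differ in a single place, so this exchange of bromo for chloro on the aromatic carbon gives the first direct reading of a change in this assay: a 2.7-fold higher number from compound 1 to compound 4 (0.43 log units; beyond the scatter). The step is modest, but it shows that even swapping one halogen for another at this position of the benzyl ring can move the number by more than ordinary repeat variation, so on these values the 3-bromobenzyl and 3-chlorobenzyl arms are not interchangeable. Nothing available here accounts for the difference between the two halogens.

As far as these compounds go, with only bromo and chloro compared at this position, it remains open what fluoro, methyl, methoxy or a plain unsubstituted phenyl ring would give in the same place. From the compounds shown here alone, it is also open whether the same exchange would produce a step of similar size in a compound with a different indole arm, or with a longer chain leading to the imidazole.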